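Adding a hydroxy group to a weakly active pair

This account rests on a few compounds, and the source may have more. Where it says the series, first, only, none or still open, it means among the compounds named here.

Compound 1 `Cc1noc(-c2cc3ccccc3[nH]2)n1` and compound 2 `c1ccc(-c2noc(-c3cc4ccccc4[nH]3)n2)cc1` share one core and differ in a single substituent. In a functional assay on MCF7 cells (Homo sapiens) for antiproliferative activity, read by WST assay, with a stated time of 72 h (a lower number here means a stronger inhibitor, a higher number a weaker inhibitor), compound 1 gives > 50000 nM, which is a limit of the assay and not a number. In this assay compound 2 gives 45700 nM. Among the measured compounds shown here, the step of an at least 1.0-fold lower number from compound 1 to compound 2 (0.03 log units; that floor lies within the scatter) is the only measured comparison, and it brings in phenyl in place of methyl on an aromatic carbon. For the measured compounds named here, compound 2 therefore holds the only real number measured here; the other value is a limit, as noted in the limit of > 50000 nM in this assay, at which 1 of the 2 values shown sits. Compound 3 `Oc1ccc2[nH]c(-c3nc(-c4ccccc4)no3)cc2c1` has not yet been measured. It differs from compound 2 by hydroxy in place of hydrogen on an aromatic carbon. Going by the values given here, no measured step touches a change of this kind: the single step from methyl to phenyl sat at a different place and stayed within the scatter, so it offers no guide. With nothing to point either way, the expectation in this assay is no step beyond the scatter. The step of a 1.1-fold lower number from compound 2 to compound 3 (0.06 log units; within the scatter) is the estimate. Compound 3 is expected to give 40000 nM, between 12000 nM and 150000 nM.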

Compound 3, half-maximal inhibitory concentration: 26000 nM
Compound 3: middle estimate off by 1.5-fold (0.19 log units), on the high side, and the stated range covers the measured number.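

Among the compounds shown here, the first measured change on the fused ring system of the shared core, hydroxy in place of hydrogen, gives a 1.8-fold lower number from compound 2 to compound 3 (0.24 log units; within the scatter) in this assay. This place, on a six-membered aromatic ring of carbon only, can therefore carry a hydroxy group without a step beyond the scatter, so neither a gain nor a loss can be claimed from this pair. The earlier step from methyl to phenyl sat at a different place on the molecule, so it could say nothing about this ring, and this pair now gives a first reading there, with real numbers on both sides.

As far as these compounds go, whether a methoxy group, an amine or a carboxylic acid at this same place would give a step beyond the scatter remains open, as does the effect of a hydroxy group elsewhere on this ring. The one value that is a limit of the assay and not a number also leaves the comparison with compound 1 without a measured size: the limit of > 50000 nM in this assay, at which 1 of the 3 values shown sits.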